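Series notes: para substituent swap on the aryloxy tail

This account rests on a few compounds, and the source may have more. Where it says the series, first, only, none or still open, it means among the compounds named here.

Measured so far:
Compound 1, `NC1=NC2(CCOCC2)N(OCCCOc2ccc(Cl)cc2)C(N)=N1`: 690 nM
Compound 2, `NC1=NC2(CCSCC2)N(OCCCOc2ccccc2Br)C(N)=N1`: 1 nM

In a functional assay on HCT-116 cells (Homo sapiens) for antiproliferative activity, read by MTT assay, with a stated time of 72 h (on this read-out lower numbers stand for stronger inhibition and higher numbers for weaker inhibition), compound 1 gives 690 nM, the highest number of the two measured. Compound 2 gives 1 nM in this assay, a far lower number; the two differ in several places at once, so the pair only shows how wide the range in the series is.

Compound 3, `Cc1ccc(OCCCON2C(N)=NC(N)=NC23CCOCC3)cc1`, is not yet measured in this assay. Against compound 1 it differs in one place: methyl in place of chloro on an aromatic carbon. Within the data shown here, no measured pair isolates this change, so there is no directly comparable step to lean on.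

The expected step from compound 1 to compound 3 in this assay is a 1.3-fold higher number from compound 1 to compound 3 (0.12 log units; within the scatter), most likely none beyond the scatter. Compound 3 is estimated at 900 nM, with a range from 300 nM to 2700 nM.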

Compound 3, half-maximal inhibitory concentration: 2390 nM
Beside the measured number, compound 3's estimate is 2.7-fold (0.42 log units) below it; low and high end bracket the measured number.
By their numbers in this assay, from the lowest: compound 2; then compound 1; then compound 3.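

Among these compounds, exchanging 4-chlorophenoxy for 4-methylphenoxy on the core of compound 1 gives, in this assay, a 3.5-fold higher number from compound 1 to compound 3 (0.54 log units; beyond the scatter) and is the first single-place change available. This position on the aromatic ring therefore responds to the exchange of one heavy atom, although the count of hydrogen-bond donors and acceptors stays the same and neither group carries a net charge; of these two groups, chloro goes with the lower number. Nothing measured here gives a reason for the step.

Still open, as far as these compounds go, is how an amine, a carboxylic acid or a longer chain in this place would compare with chloro and methyl. From the compounds shown here alone, it is equally open whether the same exchange gives a similar step on the core of compound 2.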